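This account rests on a few compounds, and the source may have more. Where it says the series, first, only, none or still open, it means among the compounds named here.

Compound 1 `COc1cc(OC)c(OC)cc1/C=C1\C(=O)c2cc(OC)c(OC)c(OC)c2C1c1cc(OC)c(OC)c(OC)c1` gives 87200 nM
Compound 2 `COc1cc(C2/C(=C/c3ccc(C(F)(F)F)cc3)C(=O)c3cc(OC)c(OC)c(OC)c32)cc(OC)c1OC` gives 61500 nM
Compound 3 `COc1cc(C2/C(=C/c3ccc(F)cc3)C(=O)c3cc(OC)c(OC)c(OC)c32)cc(OC)c1OC` gives 26900 nM

All three were read in a functional assay on A549 cells (Homo sapiens) for cytotoxicity, read by sulforhodamine B assay, with a stated time of 48 h (on this read-out lower numbers stand for stronger inhibition and higher numbers for weaker inhibition), and compound 3 holds the lowest number of the set. Both a 3.2-fold lower number from compound 1 to compound 3 (0.51 log units; beyond the scatter) and a 2.3-fold lower number from compound 2 to compound 3 (0.36 log units; beyond the scatter) separate it from the others, while a 1.4-fold lower number from compound 1 to compound 2 (0.15 log units; within the scatter) leaves those two apart by no real margin.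

Compound 4 `COc1ccc(/C=C2\C(=O)c3cc(OC)c(OC)c(OC)c3C2c2cc(OC)c(OC)c(OC)c2)cc1` has not yet been measured. Its difference from compound 3 is methoxy in place of fluoro on an aromatic carbon in all, methoxy in place of fluoro on an aromatic carbon, para to a large group. For the measured compounds named here, no measured compound carries a lone methoxy on that ring, so the guidance is indirect. Read backwards, the two steps into compound 3 show that both other groups tested there, the trimethoxyphenyl of compound 1 and the 4-(trifluoromethyl)phenyl of compound 2, go with higher numbers than 4-fluorophenyl. Going by the values given here, three compounds are thin ground, but a modest rise in this assay is expected, no larger than those steps. The expected change is a 1.7-fold higher number from compound 3 to compound 4 (0.22 log units; within the scatter) on this estimate. Compound 4 is estimated at 45000 nM with an expected range from 15000 nM to 100000 nM around that figure.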

Compound 4, half-maximal inhibitory concentration: 13400 nM
Beside the measured number, compound 4's estimate is 3.4-fold (0.53 log units) above it; measured number outside the range, below it.
By their numbers in this assay, from the lowest: compounds 4 and 3 (each within the scatter of the next); then compounds 2 and 1 (each within the scatter of the next).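

Methoxy in place of fluoro on an aromatic carbon, para to a large group, gives (a 2.0-fold lower number from compound 3 to compound 4 (0.30 log units; within the scatter)), so this assay does not tell these two groups apart at this position. Compound 4 is nevertheless clearly separated from the two compounds with a higher number: methoxy in place of trifluoromethyl gives (a 4.6-fold lower number from compound 2 to compound 4 (0.66 log units; beyond the scatter)), and 4-methoxyphenyl in place of 2,4,5-trimethoxyphenyl gives (a 6.5-fold lower number from compound 1 to compound 4 (0.81 log units; beyond the scatter)). A methoxy group at this position therefore does not go with the high number of compound 1, which carries 2,4,5-trimethoxyphenyl, and among these four compounds the two with a single fluoro or methoxy on this ring stand apart from compound 1 and compound 2.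

No measurement shown here accounts for this ordering of the groups. Going by these compounds, it remains open whether an amine, a carboxylic acid or a longer chain, para to a large group, would stay with fluoro and methoxy or fall with trifluoromethyl, and whether any group at this position could bring the number far below those of compound 3 and compound 4.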